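A few compounds are considered here, and "the series" means these few. Any claim that something is new, unique, unknown or untested is made for them only; others in the source may bear on it.

In a functional assay on SGC-7901 cells (Homo sapiens) for antiproliferative activity, read by MTT assay, with a stated time of 24 h (on this read-out lower numbers stand for stronger inhibition and higher numbers for weaker inhibition), three compounds have been measured so far. Compound 1 `Cc1cccc(NNC(=O)c2ccc(NS(=O)(=O)c3cnc(O)nc3O)cc2)c1` gives > 20000 nM, which is a limit of the assay and not a number. Compound 2 `O=C(NNc1ccccc1Cl)c1ccc(NS(=O)(=O)c2cnc(O)nc2O)cc1` gives 3630 nM. Compound 3 `O=C(NNc1cccc(Cl)c1)c1ccccc1NS(=O)(=O)c1cnc(O)nc1O` gives 10800 nM, the higher of the two exact numbers, and the gap between them lies beyond the scatter.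

Compound 4 `O=C(NNC(=O)c1ccccc1NS(=O)(=O)c1cnc(O)nc1O)c1cccc(Cl)c1` differs from compound 3 in one place: (3-chlorophenyl)carbonyl in place of 3-chlorophenyl on an amine nitrogen. In words, (3-chlorophenyl)carbonyl stands in place of 3-chlorophenyl on an amine nitrogen.

Going by the values given here, only one measured step bears on this. The step of an at least 5.5-fold lower number from compound 1 to compound 2 (0.74 log units; beyond the scatter) also changes a group on an amine nitrogen, and it lies beyond the scatter. Its size is open-ended, as the limit of > 20000 nM in this assay, at which 1 of the 3 values shown sits, marks one end of it. It shows that a change at such a nitrogen can matter, but it adds no carbonyl, so it gives no direction for this change.

In this assay, the expected result is therefore no shift beyond the scatter, with wide uncertainty. The estimated change is a 1.1-fold lower number from compound 3 to compound 4 (0.03 log units; within the scatter). For compound 4 the expected value is 10000 nM, within an estimated range of 3500 nM to 30000 nM.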

Compound 4, half-maximal inhibitory concentration: 1820 nM
Estimate against measurement, compound 4: 5.5-fold (0.74 log units) above; the measured number lies below the stated range.
By their numbers in this assay, from the lowest: compounds 4 and 2 (each within the scatter of the next); then compound 3. At a limit, above all of these: compound 1.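

Putting (3-chlorophenyl)carbonyl in place of 3-chlorophenyl on an amine nitrogen gives a 5.9-fold lower number from compound 3 to compound 4 (0.77 log units; beyond the scatter) in this assay. This is the first step shown that adds a carbonyl at this nitrogen, and it shows that the chlorophenyl ring can sit one carbonyl further out while the number falls rather than rises. Nothing shown gives a reason for this step.

Going by these compounds, the step rests on a single pair, so whether a carbonyl at this nitrogen would lower the number in the same way for the 2-chlorophenyl group of compound 2 remains open. Also open, on these data alone, is whether the ring is needed at all, as an acetyl group would test, or whether a longer chain between the carbonyl and the ring would give a similar number.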